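This account rests on a few compounds, and the source may have more. Where it says the series, first, only, none or still open, it means among the compounds named here.

Measured so far in a functional assay on KG-1 cells (Homo sapiens) for antiproliferative activity; on this read-out lower numbers stand for an effect already at smaller amounts and higher numbers for an effect only at larger amounts of compound:
compound 1 `CC(C)(C#N)CC#Cc1c(Cl)c2c(Cl)cc(C(N)=O)nc2n1[C@H]1CCCNC1`: 113 nM
compound 2 `CC(C)(O)C#Cc1c(Cl)c2c(Cl)cc(C(N)=O)nc2n1[C@H]1CCCNC1`: 302 nM

Compound 2 stands highest of the two numbers in this assay; its nearest neighbour is compound 1, and the step from one to the other is a 2.7-fold higher number from compound 1 to compound 2 (0.43 log units; beyond the scatter). Compound 3 `COC(C)(C)CC#Cc1c(Cl)c2c(Cl)cc(C(N)=O)nc2n1[C@H]1CCCNC1` has not yet been measured; it differs from compound 2 by 2-methoxy-2-methylpropyl in place of 1-hydroxy-1-methylethyl on a triple-bonded carbon. Among the measured compounds shown here, the only measured step that bears on this change is a 2.7-fold higher number from compound 1 to compound 2 (0.43 log units; beyond the scatter), in which the branched propyl chain on the triple-bonded carbon was cut back to the shorter hydroxy-bearing group. Compound 3 restores a branched propyl chain of the kind seen in compound 1, now ending in a methoxy rather than a nitrile, so the expectation is a step of about a 2.0-fold lower number from compound 2 to compound 3 (0.30 log units; within the scatter), toward the lower number of compound 1, with some uncertainty because the terminal group is not the same. Compound 3 is therefore estimated at 150 nM, with a range of 60 nM to 400 nM.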

Compound 3, half-maximal effective concentration: 172 nM
The estimate for compound 3 lay 1.1-fold (0.06 log units) below the measured number, within the range that was stated.
By their numbers in this assay, from the lowest: compounds 1, 3 and 2 (each within the scatter of the next, the first and the last beyond it).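

In this assay the move from 1-hydroxy-1-methylethyl to 2-methoxy-2-methylpropyl on a triple-bonded carbon gives a 1.8-fold lower number from compound 2 to compound 3 (0.24 log units; within the scatter) and so cannot be told apart from repeat-measurement noise. Methoxy in place of cyano on the chain gives a 1.5-fold higher number from compound 1 to compound 3 (0.18 log units; within the scatter) and is likewise unresolved, so compound 3 sits within the scatter of both compound 1 and compound 2, although those two lie beyond the scatter of each other. No supporting data are available to explain either step.

Open, going by these compounds, is how an amine or a carboxylic acid at the end of the chain, or a longer chain, would read in this assay on the same core. Also open, on these data alone, is whether a free hydroxy on the 2-methylpropyl chain would read differently from the methoxy of compound 3.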